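The compounds below may be only part of what the source reports. "The series", "measured", "known", "first", "only" and "open" are said of these compounds alone.

Compound 1, `c1ccc(CNC(c2ccc[nH]2)c2nnc(-c3ccccc3)o2)cc1`, is the parent of this small set. In a functional assay on HT-1080 cells (Homo sapiens) for cytotoxicity, read by MTT assay, with a stated time of 24 h (on this read-out higher numbers stand for weaker inhibition and lower numbers for stronger inhibition), compound 1 gives 231000 nM. Compound 2, `Clc1ccc(-c2nnc(C(NCc3ccccc3)c3ccc[nH]3)o2)cc1`, differs from it by chloro in place of hydrogen on an aromatic carbon; in this assay compound 2 gives 41000 nM, so that a 5.6-fold lower number from compound 1 to compound 2 (0.75 log units; beyond the scatter). Compound 3, `COc1ccc(CNC(c2ccc[nH]2)c2nnc(-c3ccccc3)o2)cc1`, carries a different core: it differs from compound 1 by methoxy in place of hydrogen on an aromatic carbon. In this assay compound 3 gives 175000 nM, and a 1.3-fold lower number from compound 1 to compound 3 (0.12 log units; within the scatter), a step that cannot be told apart from repeat error. Compound 4, `COc1ccc(CNC(c2ccc[nH]2)c2nnc(-c3cccc(Cl)c3)o2)cc1`, is not yet measured. It differs from compound 3 by chloro in place of hydrogen on an aromatic carbon. For the measured compounds named here, this is the same kind of change as the one from compound 1 to compound 2, but not the same one: there the chloro sits para to a large group, here it sits meta to a large group. A step of about a 3.2-fold lower number from compound 3 to compound 4 (0.50 log units; beyond the scatter) is expected from compound 3 to compound 4, somewhat smaller than the earlier step, and this rests on one pair only, compound 1 and compound 2, where a 5.6-fold lower number from compound 1 to compound 2 (0.75 log units; beyond the scatter). Compound 4 is therefore estimated to give 55000 nM in this assay, expected to fall between 22000 nM and 150000 nM.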

Compound 4, half-maximal inhibitory concentration: 84600 nM
Compound 4: middle estimate off by 1.5-fold (0.19 log units), on the low side; the measured number falls inside the stated range.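

In this assay, chloro in place of hydrogen again gives a lower number, a 2.1-fold lower number from compound 3 to compound 4 (0.32 log units; beyond the scatter), so on these two cores the change points the same way. The size of the step, however, does not carry over unchanged: the same change on two cores in this assay, a 5.6-fold lower number (0.75 log units; beyond the scatter) from compound 1 to compound 2 and a 2.1-fold lower number (0.32 log units; beyond the scatter) from compound 3 to compound 4, 2.7-fold (0.44 log units) apart, beyond the scatter of two such steps. This does not show that the core alone sets the size, since the chloro in compound 4 sits meta to a large group while the chloro in compound 2 sits at a different place on its ring, and the two pairs cannot separate the effect of the core from that of the position.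

The compounds shown leave open what the chloro would do at one and the same place on both cores, which would allow a cleaner comparison of the two cores. They also leave open whether a bromo group, a nitrile or a carboxylic acid on that ring would shift the number in the same direction as chloro.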